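Naphthalenyl Replaces Chlorofluorobenzyl on a Furfurylamine Quinoline

The compounds below may be only part of what the source reports. "The series", "measured", "known", "first", "only" and "open" are said of these compounds alone.

Of the compounds shown here, three sharing one core have been measured in an ADME assay for permeability, using PAMPA, with a stated time of 30 min, at pH 7.4; on this read-out higher numbers stand for higher permeability and lower numbers for lower permeability. Compound 1 `CC(C)(C)c1ccc(-c2ccc3c(NCCCNCc4ccco4)ccnc3c2)cc1` gives 237 10^-6 cm/s, compound 2 `c1ccc(Oc2ccc3c(NCCCNCc4ccco4)ccnc3c2)cc1` gives 317 10^-6 cm/s, and compound 3 `Fc1ccc(Cc2ccc3c(NCCCNCc4ccco4)ccnc3c2)c(Cl)c1` gives 23 10^-6 cm/s. Compound 3 thus stands lowest of the three: the step from compound 1 to compound 3 was a 10-fold lower number from compound 1 to compound 3 (1.01 log units; beyond the scatter), and that from compound 2 to compound 3 was a 14-fold lower number from compound 2 to compound 3 (1.14 log units; beyond the scatter), both large, whereas the step from compound 1 to compound 2 was a 1.3-fold higher number from compound 1 to compound 2 (0.13 log units; within the scatter).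

Compound 4 `c1coc(CNCCCNc2ccnc3cc(-c4cccc5ccccc45)ccc23)c1` is the next member. Relative to compound 3 the change is naphthalen-1-yl in place of 2-chloro-4-fluorobenzyl on an aromatic carbon. The two large steps that bear on it, from compound 1 to compound 3 and from compound 2 to compound 3, both ran downward when the 2-chloro-4-fluorobenzyl group entered; the present change removes that group again and brings in a substituent attached, as in compound 1 and compound 2, directly to the core. An upward step in this assay is therefore expected, though its size is uncertain. Compound 4 is estimated at 150 10^-6 cm/s, with a range from 40 10^-6 cm/s to 350 10^-6 cm/s, which would mean an expected step of a 6.5-fold higher number from compound 3 to compound 4 (0.81 log units; beyond the scatter).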

Compound 4, apparent permeability: 237 10^-6 cm/s
Beside the measured number, compound 4's estimate is 1.6-fold (0.20 log units) below it; measured number inside the range.
By their numbers in this assay, from the lowest: compound 3; then compounds 1, 4 and 2 (each within the scatter of the next).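

On the same aromatic carbon of the shared core, naphthalen-1-yl in place of 2-chloro-4-fluorobenzyl gives a large step in this assay (a 10-fold higher number from compound 3 to compound 4 (1.01 log units; beyond the scatter)), so compound 3 now stands as the lowest of four, apart from each of the others by more than the scatter. The new group cannot be told from phenoxy (a 1.3-fold lower number from compound 2 to compound 4 (0.13 log units; within the scatter)) or from 4-(tert-butyl)phenyl (no change at the digits printed from compound 1 to compound 4 (within the scatter)), which means that three groups of different shape and size, one of them with two six-membered aromatic rings of carbon only, now sit together at this position, and only the 2-chloro-4-fluorobenzyl group of compound 3 goes against that grouping. The step from compound 3 to compound 4 removes the chlorine, the fluorine and the benzyl attachment in a single change, so these compounds cannot assign the large gap to any one of them.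

From the compounds shown here alone, a plain benzyl group, or a 2-chlorophenyl group, at the same carbon would separate those parts of the change, and whether an amine such as morpholine would stay with the upper three remains open. Nothing measured here explains why compound 3 stands apart.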